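Ring Size at the Carbonyl and Maximal Calcium Response

The compounds below may be only part of what the source reports. "The series", "measured", "known", "first", "only" and "open" are said of these compounds alone.

Of the compounds shown here, three sharing one core have been measured in an assay on CHO cells for agonist activity at Neuronal acetylcholine receptor; alpha3/alpha6/beta2/beta3 (Homo sapiens), read by FLIPR and calcium flux; a higher number here means a larger maximal response, a lower number a smaller maximal response. Compound 1 `CCCC(=O)N1CC2CC(C1)N2` gives 92%. Compound 2 `O=C(C1CCC1)N1CC2CC(C1)N2` gives 80%, and compound 3 `O=C(C1CCCC1)N1CC2CC(C1)N2` gives 62%. Among these three numbers compound 2 stands second highest: compound 1 lies above it, beyond the scatter, and compound 3 lies below it, also beyond the scatter. Among the measured compounds shown here, the one step between neighbours differing in a single place is a number 12 percentage points lower from compound 1 to compound 2 (beyond the scatter), a modest loss on moving from an open chain to a ring. The unmeasured compound 4 `C[C@H]1C[C@H]1C(=O)N1CC2CC(C1)N2` differs from compound 2 as follows: 2-methylcyclopropyl in place of cyclobutyl on a carbonyl carbon. For the measured compounds named here, the only step that bears on this change is the move from compound 1 to compound 2, and the values of compound 2 and compound 3 show a further fall with the larger ring. Compound 4 carries a smaller ring than compound 2 but with a methyl on it, so a step of a number 2 percentage points higher from compound 2 to compound 4 (within the scatter) in this assay is expected, within the scatter either way. For compound 4 the expected value is 82%, with a range from 64% to 96%.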

Compound 4, largest response reached (Emax), in percent of the reference or control that the assay uses: 60%
For compound 4 the middle estimate is 22 percentage points above the measured one; the whole stated range lies above it.
By their numbers in this assay, from the lowest: compounds 4 and 3 (each within the scatter of the next); then compound 2; then compound 1.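

In this assay, exchanging cyclobutyl for 2-methylcyclopropyl on the carbonyl carbon, two groups with the same heavy-atom count, gives a number 20 percentage points lower from compound 2 to compound 4 (beyond the scatter) and so shows that this position responds to more than that count. Measured against the open propyl chain, the same group gives a number 32 percentage points lower from compound 1 to compound 4 (beyond the scatter), the largest step yet seen here. The earlier fall with growing ring size from compound 1 through compound 2 to compound 3 does not extend to compound 4, which carries the smallest ring yet stands within the scatter of compound 3, so ring size alone does not order these compounds.

No evidence at hand accounts for this loss. Still open, on these data alone, is how plain cyclopropyl or cyclohexyl would compare, and whether the methyl or its defined stereocentres matter here.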